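The source may hold more compounds than are shown below. What is called first, only, known or untested is meant among the compounds shown, and "the series" means these compounds.

Measured compounds in an assay on isolated protein (kidney, strain Wistar) for displacement of a labelled ligand from Translocator protein (Rattus norvegicus), read by scintillation counting, with a stated time of 90 min; a lower number here means a stronger inhibitor, a higher number a weaker inhibitor:
- compound 1 `CCN(CC)C(=O)Cc1c(-c2ccc(OC3CCC3)cc2)nn2c(C)cc(C)nc12` gives 0.86 nM
- compound 2 `CCN(CC)C(=O)Cc1c(-c2ccc(OCC3CC3)cc2)nn2c(C)cc(C)nc12` gives 3 nM
- compound 3 `CCN(CC)C(=O)Cc1c(-c2ccc(OCc3ccccc3)cc2)nn2c(C)cc(C)nc12` gives 0.99 nM

Compound 3 stands second highest of the three numbers. Its nearest neighbour is compound 1, with a 1.2-fold higher number from compound 1 to compound 3 (0.06 log units; within the scatter) between them, a gap within the scatter; compound 2 is furthest, with a 3.0-fold lower number from compound 2 to compound 3 (0.48 log units; beyond the scatter). The other comparison, a 3.5-fold higher number from compound 1 to compound 2 (0.54 log units; beyond the scatter), shows that the group on the aromatic oxygen can move the number by a modest amount, while swapping the cyclobutyl for benzyl leaves it unchanged.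

Compound 4 `CCN(CC)C(=O)Cc1c(-c2ccc(OCc3ccc(C(F)(F)F)cc3)cc2)nn2c(C)cc(C)nc12` differs from compound 3 by trifluoromethyl in place of hydrogen on an aromatic carbon. Among the measured compounds shown here, no measured pair in this set varies a substituent on the phenyl of the benzyl group, so none of the three steps bears directly on this change. The steps that touch the same region, a 3.0-fold lower number from compound 2 to compound 3 (0.48 log units; beyond the scatter) and a 1.2-fold higher number from compound 1 to compound 3 (0.06 log units; within the scatter), are modest or within the scatter, which suggests this region tolerates variation without large shifts. The change is therefore expected to give a step of no more than modest size, direction uncertain, and possibly none beyond the scatter.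

The expected step in this assay is a 1.5-fold higher number from compound 3 to compound 4 (0.18 log units; within the scatter). Compound 4 is therefore estimated at 1.5 nM, with a range of 0.4 nM to 6 nM.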

Compound 4, inhibition constant: 1.6 nM
The estimate for compound 4 lay 1.1-fold (0.03 log units) below the measured number; the measured number falls inside the stated range.
By their numbers in this assay, from the lowest: compounds 1, 3, 4 and 2 (each within the scatter of the next, the first and the last beyond it).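

In this assay, among the compounds shown here, the benzyl group on the oxygen carries a trifluoromethyl on its phenyl ring with no step beyond the scatter (a 1.6-fold higher number from compound 3 to compound 4 (0.21 log units; within the scatter)), the first evidence that this outer ring accepts a substituent in place of hydrogen. Compound 4 also cannot be separated from either of the other two ether groups (a 1.9-fold higher number from compound 1 to compound 4 (0.27 log units; within the scatter); a 1.9-fold lower number from compound 2 to compound 4 (0.27 log units; within the scatter)), whereas compound 2 stands apart beyond the scatter from both compound 1 and compound 3, so 4-(trifluoromethyl)benzyl falls within the scatter of both sides of that earlier gap. No measured evidence is available to explain this result.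

As far as these compounds go, the reading rests on one substituent at one ring carbon, so it remains open whether a carboxylic acid, a primary amine or a methoxy group on that carbon would also stay within the scatter of compound 3 in this assay (same read-out). From the compounds shown here alone, it is equally open whether trifluoromethyl on a different carbon of that phenyl ring, or a longer chain between the oxygen and the ring, would keep the number in the same range.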